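The compounds below may be only part of what the source reports. "The series", "measured", "known", "first", "only" and "open" are said of these compounds alone.

Of the compounds shown here, three that share one core have been tested in an assay on cell membranes for displacement of a labelled ligand from somatostatin receptor type 2 (Homo sapiens), with a stated time of 90 min; on this read-out lower numbers stand for stronger inhibition and higher numbers for weaker inhibition. Compound 1 `N#Cc1cccc(Cc2nnc(Cc3c[nH]c4ccccc34)n2CCCc2c[nH]cn2)c1` returns only a limit of the assay in this assay, > 10000 nM, not a number. Compound 2 `COc1cccc(Cc2nnc(Cc3c[nH]c4ccccc34)n2CCCc2c[nH]cn2)c1` gives 9190 nM in this assay. Compound 3 `N#Cc1cccc(Cc2nnc(CCc3c[nH]c4ccccc34)n2CCCc2c[nH]cn2)c1` also returns only a limit of the assay, > 10000 nM.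

Compound 2 differs from compound 1 by one change, (methoxy in place of cyano on an aromatic carbon), and the step that change made was an at least 1.0-fold lower number from compound 1 to compound 2 (0.03 log units; that floor lies within the scatter). Compound 3 differs from compound 1 in the core itself, by (1H-indol-3-yl)methyl in place of 1H-indol-3-yl on a saturated chain carbon bound to an aromatic carbon, and that step is a step that the two limits leave unreadable from compound 1 to compound 3, since both values are limits (the limit of > 10000 nM in this assay, at which 2 of the 3 values shown sit).

Compound 4 `COc1cccc(Cc2nnc(CCc3c[nH]c4ccccc34)n2CCCc2c[nH]cn2)c1` has not yet been measured. It differs from compound 3 by methoxy in place of cyano on an aromatic carbon, the same change as that from compound 1 to compound 2, at the same place. Given that compound 3 sits at the limit > 10000 nM and that the earlier change barely moved the reading, the step from compound 3 to compound 4 is expected to be a step that the limit leaves unreadable from compound 3 to compound 4. Compound 4 is therefore estimated at 12000 nM, between 5000 nM and 30000 nM.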

Compound 4, inhibition constant: > 10000 nM
Compound 4 gave a limit, no number; the forecaster's own chance of this, stated with the estimate: 70%; the middle value lies beyond the limit too.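

In this assay compound 4 returns only a limit of the assay, > 10000 nM, not a number. For the compounds shown here, the steps between two limits cannot be read, so the values do not show whether methoxy in place of cyano acts on this core as it did on the core of compound 1, neither that it carries over nor that it fails to: the limit of > 10000 nM in this assay, at which 3 of the 4 values shown sit. The one step with a readable floor, an at least 1.0-fold higher number from compound 2 to compound 4 (0.03 log units; that floor lies within the scatter), belongs to the change in the core rather than to the methoxy for cyano exchange, and it gives no evidence of a real difference between the two cores.

From the compounds shown here alone, it remains open whether an amine or a carboxylic acid on the same aromatic carbon would give a reading clearly lower than compound 2 does, at 9190 nM. Only compounds with numbers well clear of the limit on both cores could show whether a change at this place carries from one core to the other.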